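The compounds below may be only part of what the source reports. "The series", "measured", "known", "first", "only" and "open" are said of these compounds alone.

Measured in a functional assay on the whole organism (strain Hartley) for inhibition, with Cavia porcellus as the target, with stated times of 15 min and 2 min; a lower number here means that less compound is needed, a higher number that more compound is needed for the effect:
- compound 1 `CCCCC1([C@H](O)/C=C/C2CCC(=O)[C@@H]2CCCCCC(=O)O)CCC1`: 0.32 mg/kg
- compound 2 `CCCCC1([C@H](O)/C=C/C2CCC(=O)[C@@H]2CCCCSCC(=O)OCC)CCC1`: 0.909 mg/kg
- compound 3 `CCCCC1([C@H](O)/C=C/C2CCC(=O)[C@@H]2C/C=C\CCCC(=O)O)CCC1`: 0.0242 mg/kg

Compound 3 has the lowest number of the three, at 0.0242 mg/kg, so less of it is needed than of either other compound.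

The next structure is compound 4 `CCCCC1([C@H](O)/C=C/C2CCC(=O)[C@@H]2CCCCCCC(=O)O)CCC1`. The change is 5-carboxypentyl in place of 5-carboxypent-1-en-1-yl on a saturated chain carbon bound to a saturated ring carbon.

The most relevant measured step is a 13-fold lower number from compound 1 to compound 3 (1.12 log units; beyond the scatter). It replaced 4-carboxybutyl with 5-carboxypent-1-en-1-yl, so chain length and the double bond changed together. For the measured compounds named here, no measured pair separates the two, and compound 4 keeps the chain length of compound 3 while losing the double bond. The whole of that large step is therefore unlikely to be lost, and compound 1 at 0.32 mg/kg serves as a rough upper reference. The other step, a 2.8-fold higher number from compound 1 to compound 2 (0.45 log units; beyond the scatter), changes a different part of the chain and its acid end, so it bears little on this question.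

A partial loss in this assay is expected, with the number moving upward, and the expected size is a 2.9-fold higher number from compound 3 to compound 4 (0.46 log units; beyond the scatter). For compound 4 the estimated value is 0.07 mg/kg, with an expected range from 0.02 mg/kg to 0.3 mg/kg.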

Compound 4, dose for half-maximal effect: 47.8 mg/kg
For compound 4 the middle estimate is 680-fold (2.83 log units) below the measured one, and the stated range ends below it.
By their numbers in this assay, from the lowest: compound 3; then compound 1; then compound 2; then compound 4.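

In this assay, a 2000-fold higher number from compound 3 to compound 4 (3.30 log units; beyond the scatter) with 5-carboxypentyl in place of 5-carboxypent-1-en-1-yl on a saturated chain carbon bound to a saturated ring carbon, so at this chain length the double bond is the only difference; the earlier step from compound 1 to compound 3 changed chain length and double bond together and could not show this. The saturated chains also differ sharply from each other, with a 150-fold higher number from compound 1 to compound 4 (2.17 log units; beyond the scatter) for carboxymethyl in place of carboxy, and a 53-fold higher number from compound 2 to compound 4 (1.72 log units; beyond the scatter) for 2-carboxyethyl in place of ((ethoxycarbonyl)methyl)sulfanyl, so within this set the longer saturated acid chain has the highest number. Nothing available explains the size of these steps.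

The sulfur and the ethyl ester of compound 2 change together, so their separate contributions remain unresolved, as does the effect of a double bond on the shorter chain of compound 1. Also open, going by these compounds, is whether a triple bond in place of the double bond, or an ethyl ester on 5-carboxypent-1-en-1-yl, would keep a number near that of compound 3 at 0.0242 mg/kg.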